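From a Pyrrole Ketone to an Aminopyrimidine Ketone

This account rests on a few compounds, and the source may have more. Where it says the series, first, only, none or still open, it means among the compounds named here.

Compound 2 `COc1ccc(-c2cc3ccccc3nc2/C=C/C(=O)c2ccc[nH]2)cc1` is known in a functional assay on A549 cells (Homo sapiens) for antiproliferative activity, read by XTT assay, with a stated time of 72 h (on this read-out lower numbers stand for stronger inhibition and higher numbers for weaker inhibition), only as a limit, and there compound 2 gives > 10000 nM. Compound 1 `COc1ccc(-c2cc3ccccc3nc2/C=C/C(=O)c2ccc(OC)cc2OC)cc1` gives 7990 nM in this assay, so the step of an at least 1.2-fold higher number from compound 1 to compound 2 (0.09 log units; that floor lies within the scatter) rests on that limit (the limit of > 10000 nM in this assay, at which 1 of the 2 values shown sits). Compound 3 `COc1ccc(-c2cc3ccccc3nc2/C=C/C(=O)c2cnc(N)nc2C)cc1` carries the change (2-amino-4-methylpyrimidin-5-yl in place of 1H-pyrrol-2-yl on a carbonyl carbon). Within the data shown here, only that single measured step bears on it, and it shows no more than the floor of a weakening. Compound 3 is therefore expected to remain near the limit, with the step that the limit leaves unreadable from compound 2 to compound 3 meaning no movement beyond the scatter. The estimate for compound 3 is 15000 nM, between 4000 nM and 60000 nM.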

Compound 3, half-maximal inhibitory concentration: > 10000 nM
Compound 3: a limit, no number; the forecaster's own chance of this, stated with the estimate: 60%; the middle value does not contradict the limit.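

A second aromatic ring with hetero atoms, here six-membered rather than five-membered, also ends at the assay's limit on this carbonyl carbon, so that outcome is not confined to 1H-pyrrol-2-yl: the limit of > 10000 nM in this assay, at which 2 of the 3 values shown sit.

Replacing 2,4-dimethoxyphenyl with 2-amino-4-methylpyrimidin-5-yl gives an at least 1.2-fold higher number from compound 1 to compound 3 (0.09 log units; that floor lies within the scatter). The step between compound 2 and compound 3 cannot be read, as both values are limits.

Going by these compounds, how far compound 2 and compound 3 lie past the limit remains open. So does what a 3,4,5-trimethoxyphenyl or a pyridin-3-yl group would give on this carbonyl carbon.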